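The source may report more compounds than this note shows. Statements on the series, on what has been measured and on what is new or still open speak of the compounds shown alone.

Working notes on the series

Of the compounds shown here, three have been measured in a functional assay on Huh-7 cells (Homo sapiens) for inhibition, read by sulforhodamine B assay, with a stated time of 72 h; a lower number here means a stronger inhibitor, a higher number a weaker inhibitor. Compound 1 `CC(c1ccc(-c2ccccc2)c(F)c1)c1nnc2n1N=C(c1ccccc1)CS2` gives 6700 nM. Compound 2 `CC(c1ccc(-c2ccccc2)c(F)c1)c1nnc2n1N=C(c1ccc(C(F)(F)F)cc1)CS2` gives 9400 nM. Compound 3 `CC(C)Cc1ccc(C(C)c2nnc3n2N=C(c2ccc(C(F)(F)F)cc2)CS3)cc1` gives 8400 nM. All three numbers lie within the usual scatter of one another, so no order among them is claimed.

Compound 2 and compound 1 differ in one place only, (hydrogen in place of trifluoromethyl on an aromatic carbon), and the step that this change made in this assay is a 1.4-fold lower number from compound 2 to compound 1 (0.15 log units; within the scatter).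

Compound 4 `CC(C)Cc1ccc(C(C)c2nnc3n2N=C(c2ccccc2)CS3)cc1` has not yet been measured in this assay . It differs from compound 3 in one place, (hydrogen in place of trifluoromethyl on an aromatic carbon). This is the same change that separates compound 2 from compound 1, at a place that is described in the same words for both pairs. The difference between the core of compound 3 and the core of compound 2 is not broken down here.

For the measured compounds named here, since the only recorded instance of this change, the step of a 1.4-fold lower number from compound 2 to compound 1 (0.15 log units; within the scatter), stays within the scatter, the expectation for compound 4 in this assay is a step of similar size, a 1.4-fold lower number from compound 3 to compound 4 (0.15 log units; within the scatter), and it is expected to also stay within the scatter. On that basis compound 4 is estimated at 6000 nM in this assay , with a range of 3000 nM to 12000 nM. This expectation rests on one pair alone, compound 2 and compound 1, and the cores of compound 3 and compound 2 are different, so the estimate is held loosely.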

Compound 4, half-maximal inhibitory concentration: 6100 nM
Compound 4: the middle estimate sits 1.0-fold (0.01 log units) below what was measured, within the range that was stated.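

In this assay, for the compounds shown here, hydrogen in place of trifluoromethyl on an aromatic carbon now gives a second step, a 1.4-fold lower number from compound 3 to compound 4 (0.14 log units; within the scatter), and it can be set beside the first instance on the other core: the same change on two cores in this assay, a 1.4-fold lower number (0.15 log units; within the scatter) from compound 2 to compound 1 and a 1.4-fold lower number (0.14 log units; within the scatter) from compound 3 to compound 4, 1.0-fold (0.01 log units) apart, within the scatter of two such steps. Across these two pairs, the replacement of 4-(trifluoromethyl)phenyl by phenyl therefore reads the same on both cores, and nothing here separates the step on one core from the step on the other. Going by these compounds alone, this does not show that the change has a real effect in this assay, since each step stays within the scatter, and agreement between two steps of this small size is a weak test of transfer: it says only that neither core departs from the other here, and nothing about any further core.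

The compounds shown carry only hydrogen or trifluoromethyl at this place, so it remains open whether a different group there, such as an amine, a carboxylic acid or a nitrile, would give a step beyond the scatter. From the compounds shown here alone, it also remains open whether such a step, if found, would carry from one core to the other in the same way.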